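From compound 3 to a cyclopropyl group

The source may hold more compounds than are shown below. What is called first, only, known or untested is meant among the compounds shown, and "the series" means these compounds.

In a functional assay on MGC-803 cells (Homo sapiens) for inhibition, read by MTT assay, with a stated time of 48 h (a lower number here means a stronger inhibitor, a higher number a weaker inhibitor), compound 1 (`COCC(=O)N(Cc1ccc(OC)c(O)c1)c1cc(OC)c(OC)c(OC)c1`) gives 79 nM and compound 2 (`COc1ccc(CN(C(=O)/C=C/CBr)c2cc(OC)c(OC)c(OC)c2)cc1O`) gives 71 nM, which is a 1.1-fold lower number from compound 1 to compound 2 (0.05 log units; within the scatter). Compound 3 (`COc1ccc(CN(C(=O)C[Se]C#N)c2cc(OC)c(OC)c(OC)c2)cc1O`) gives 270 nM, the highest of the three numbers. Compound 4 (`COc1ccc(CN(C(=O)C2CC2)c2cc(OC)c(OC)c(OC)c2)cc1O`) differs from it by a group of 3 heavy atoms (3 carbon; one three-membered non-aromatic ring of carbon only) in place of a group of 4 heavy atoms (2 carbon, 1 nitrogen, 1 selenium; no ring), on a carbonyl carbon.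

Among the compounds with values here, no measured compound carries cyclopropyl, so the evidence is indirect. The relevant steps are a 3.4-fold higher number from compound 1 to compound 3 (0.53 log units; beyond the scatter) and a 3.8-fold higher number from compound 2 to compound 3 (0.58 log units; beyond the scatter), both modest. Leaving the group of compound 3 may therefore recover part of that gap, so a modest step to a lower number is expected in this assay. The estimated change is a 2.3-fold lower number from compound 3 to compound 4 (0.35 log units; beyond the scatter). Compound 4 is expected at 120 nM, with an estimated range of 35 nM to 400 nM.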

Compound 4, half-maximal inhibitory concentration: 59 nM
Compound 4: the middle estimate sits 2.0-fold (0.31 log units) above what was measured; the measured number falls inside the stated range.
By their numbers in this assay, from the lowest: compounds 4, 2 and 1 (each within the scatter of the next); then compound 3.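

In this assay, a ring on this carbonyl carbon is tolerated: replacing the selenium- and nitrogen-bearing group with cyclopropyl gives a modest gain (a 4.6-fold lower number from compound 3 to compound 4 (0.66 log units; beyond the scatter)). Cyclopropyl also stays level with the two open-chain groups (a 1.2-fold lower number from compound 2 to compound 4 (0.08 log units; within the scatter); a 1.3-fold lower number from compound 1 to compound 4 (0.13 log units; within the scatter)), so among these four compounds only compound 3 stands apart. Nothing available explains these differences.

The compounds shown leave open whether a larger ring, such as cyclobutyl or cyclohexyl, would hold this level. They also leave open how an amine or a carboxylic acid would fare on this carbonyl carbon.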